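Trimming the Amide Chain: Expected Cell Tolerance

This account rests on a few compounds, and the source may have more. Where it says the series, first, only, none or still open, it means among the compounds named here.

Measured compounds:
Compound 1, `CCCC(=O)Nc1ncc(-c2ccc(OC)cc2)n1C`: in a toxicity assay on THP-1 cells (Homo sapiens) for inhibition (a higher number here means that more compound is tolerated, a lower number that less compound is tolerated), compound 1 gives > 100000 nM, which is a limit of the assay and not a number.
Compound 2, `CCn1c(-c2ccc(OC)cc2)cnc1NC(=O)c1ccc(F)cc1`: in this assay compound 2 gives > 100000 nM, again a limit.
Compound 3, `Cn1c(-c2ccccc2)cnc1NC(=O)c1ccccc1Cl`: in this assay compound 3 gives > 50000 nM, also a limit.

Compound 1 therefore stands not at a number but at a ceiling of the measurement: the cells tolerated every amount tested. It shares this with compound 2, both sitting at the limit of > 100000 nM in this assay, at which 2 of the 3 values shown sit, while compound 3 sits at the limit of > 50000 nM in this assay, at which 1 of the 3 values shown sits, a lower ceiling that still reports no toxicity within the tested range. Going by the values given here, no two of these three compounds differ in only one place, so no measured step in this assay is available to set a scale.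

Compound 4, `COc1ccc(-c2cnc(NC(C)=O)n2C)cc1`, is the next compound. Compared with compound 1 the change is hydrogen in place of ethyl on a saturated chain carbon bound to a carbonyl carbon. The shared core and the methoxyphenyl group stay as they are; only the chain on the amide carbonyl is shortened.

Given that compound 1 sits at the ceiling (the limit of > 100000 nM in this assay, at which 2 of the 3 values shown sit), removing two chain carbons is expected to change tolerance by nothing beyond the scatter, the step of a number no higher from compound 1 to compound 4 (the limit leaves the size open) being my expectation. For compound 4 the estimate in this assay is 100000 nM, within 50000 nM to 200000 nM, most likely reported again only as a limit.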

Compound 4, half-maximal cytotoxic concentration: > 100000 nM
Compound 4: a limit, no number; the forecaster's own chance of this, stated with the estimate: 85%; the middle value sits exactly at the limit.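

Compound 1 and compound 4 both end at a limit of the measurement rather than at a number, so the step from propyl to methyl between them cannot be read. The compounds shown leave open at what concentration, if any, each would reach half-maximal toxicity in this assay, and whether the chain's length matters there at all.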